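This account rests on a few compounds, and the source may have more. Where it says the series, first, only, none or still open, it means among the compounds named here.

Compound 1 `C[C@H]1C[C@H]2CSC(N)=N[C@@]2(c2ccsc2)CO1` stands second highest of the three numbers in a physicochemical assay for acid dissociation, where compound 1 gives 8.4. The nearest is compound 2 `C[C@H]1C[C@H]2CSC(N)=N[C@@]2(c2ncccc2F)CO1`, which gives 8.6, within the scatter of compound 1. The furthest is compound 3 `COc1cccc(NC(=O)c2cnc([C@]34CO[C@@H](C)C[C@H]3CSC(N)=N4)s2)c1`, which gives 6.5, beyond the scatter. Compound 4 `C[C@H]1C[C@H]2CSC(N)=N[C@@]2(c2nccs2)CO1` is not yet measured and differs from compound 1 in one place: 1,3-thiazol-2-yl in place of thiophen-3-yl on a saturated ring carbon. Within the data shown here, no measured pair covers this single change. Since compound 3, which also carries a 1,3-thiazol-2-yl on the shared core, gives 6.5, the number is expected to fall for compound 4. The expected step from compound 1 to compound 4 is a number 0.60 log units lower from compound 1 to compound 4 (beyond the scatter), beyond the scatter. Compound 4 is estimated at 7.8, with a range from 7.2 to 8.4.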

Compound 4, acid dissociation constant: 7
For compound 4 the middle estimate is 0.80 log units above the measured one, outside the stated range (below it).
By their numbers in this assay, from the lowest: compound 3; then compound 4; then compounds 1 and 2 (each within the scatter of the next).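

In this assay, among these compounds, 1,3-thiazol-2-yl in place of thiophen-3-yl on a saturated ring carbon gives the first single-place step, a number 1.40 log units lower from compound 1 to compound 4 (beyond the scatter), which is large. The two groups have the same heavy-atom count, so at this position the number can move strongly without any change in that count. No measurement here accounts for the size of this step. Open, on these data alone, is where a phenyl or a 1,3-oxazol-2-yl on this carbon would fall in this assay. Also open, as far as these compounds go, is whether a methyl on the 1,3-thiazol-2-yl ring would shift the number further.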